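The source may report more compounds than this note shows. Statements on the series, on what has been measured and on what is new or still open speak of the compounds shown alone.

The measured compounds:
Compound 1 `O=C(Nc1ccccc1)c1c(NO)cc(-c2ccccc2)oc1=O` gives 11600 nM in an ADME assay on Huh-7 cells (Homo sapiens) for cytotoxicity, read by a luciferase reporter and WST assay, with a stated time of 3 days; a lower number here means that less compound is tolerated, a higher number that more compound is tolerated.
Compound 2 `O=C(Nc1ccc(Br)cc1)c1c(NO)cc(-c2ccccc2)oc1=O` gives > 20000 nM in this assay, which is a limit of the assay rather than a number.
Compound 3 `Cc1ccc(NC(=O)c2c(NO)cc(-c3ccccc3)oc2=O)cc1` gives > 20000 nM in this assay, again a limit of the assay rather than a number.

So compound 3 stands at the upper edge of what this assay reports, and its true value is only known to lie beyond that limit; compound 2 sits at the same limit, as noted in the limit of > 20000 nM in this assay, at which 2 of the 3 values shown sit. Compound 4 `Cc1ccc(NC(=O)c2c(NO)cc(-c3ccc(C)cc3)oc2=O)cc1` differs from compound 3 by methyl in place of hydrogen on an aromatic carbon. Going by the values given here, the one measured step of the same kind, an at least 1.7-fold higher number from compound 1 to compound 3 (0.23 log units; that floor lies within the scatter), was a move to the limit. The step of an at least 1.7-fold higher number from compound 1 to compound 2 (0.23 log units; that floor lies within the scatter) also reached the limit, and a step that the two limits leave unreadable from compound 2 to compound 3 cannot be read. A second methyl added in this way is therefore expected to leave compound 4 at or beyond the same limit, with no readable change from compound 3, so the expected step that the limit leaves unreadable from compound 3 to compound 4 is small. For compound 4 the estimated value in this assay is 25000 nM, within 12000 nM to 60000 nM.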

Compound 4, half-maximal cytotoxic concentration: > 20000 nM
Compound 4 was reported as a limit (the forecaster's own chance of this, stated with the estimate: 70%); the middle value does not contradict the limit.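

The step from compound 3 to compound 4 cannot be read, since both compounds are reported only as the same limit in this assay: the limit of > 20000 nM in this assay, at which 3 of the 4 values shown sit.

As far as these compounds go, how far beyond that limit compound 2, compound 3 and compound 4 truly lie stays open, and so does whether going from phenyl to 4-methylphenyl changes the tolerated concentration at all.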